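The source may report more compounds than this note shows. Statements on the series, on what has been measured and on what is new or still open speak of the compounds shown alone.

Of the compounds shown here, three have been measured in a physicochemical assay for solubility, with a stated time of 18 h, at pH 7.4; a lower number here means a less soluble compound, a higher number a more soluble compound. Compound 2 `Fc1ccc(-c2ccc3c(NCCCNCc4ccco4)ccnc3c2)cc1` gives 32000 nM. Compound 3 `COc1ccc(-c2ccc3c(NCCCNCc4ccco4)ccnc3c2)cc1` differs from compound 2 only by methoxy in place of fluoro on an aromatic carbon; in this assay compound 3 gives 32000 nM, and the step of no change at the digits printed from compound 2 to compound 3 (within the scatter). Compound 1 `COc1ccc(Oc2ccc3c(NCCCNCc4cc(F)ccc4OC)ccnc3c2)cc1` gives 14500 nM, a number lower than that of compound 2 by more than the scatter. Compound 2 therefore stands level with compound 3, the two together holding the highest numbers of the three, with compound 1 the furthest away.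

Compound 4 `COc1ccc(F)cc1CNCCCNc1ccnc2cc(-c3ccc(F)cc3)ccc12` is compound 2 with 5-fluoro-2-methoxyphenyl in place of furan-2-yl on a saturated chain carbon bound to an amine nitrogen. Among the compounds with values here, no measured step covers this change; the single step, from compound 2 to compound 3, altered a different part of the molecule and says nothing about it. Within the data shown here, the only hint is that compound 1 carries the same 5-fluoro-2-methoxybenzyl group on another core and gives 14500 nM, the lowest number seen. Compound 4 is therefore expected to give 20000 nM, somewhere between 8000 nM and 45000 nM, the expected step of a 1.6-fold lower number from compound 2 to compound 4 (0.20 log units; within the scatter) being downward and small enough that it may not pass the scatter.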

Compound 4, solubility: 32000 nM
Compound 4: middle estimate off by 1.6-fold (0.20 log units), on the low side; the range from low to high includes it.
By their numbers in this assay, from the lowest: compound 1; then compounds 2, 3 and 4 (each within the scatter of the next).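

In this assay the result of putting 5-fluoro-2-methoxyphenyl in place of furan-2-yl on a saturated chain carbon bound to an amine nitrogen is no change at the digits printed from compound 2 to compound 4 (within the scatter) and so, on this core, this position accepts the larger aromatic ring without a visible shift. Putting 4-fluorophenyl in place of 4-methoxyphenoxy on an aromatic carbon gives a 2.2-fold higher number from compound 1 to compound 4 (0.34 log units; beyond the scatter) and so the lower number of compound 1 goes with its 4-methoxyphenoxy group, not with the 5-fluoro-2-methoxybenzyl group that compound 1 and compound 4 share. No measurement shown explains either step.

Going by these compounds, both groups compared at this position are aromatic rings, so the effect of a carboxylic acid or a plain alkyl chain there remains open. On these data alone, it is also open whether the 5-fluoro-2-methoxybenzyl group would behave the same way alongside other groups on the shared core.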